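A few compounds are considered here, and "the series" means these few. Any claim that something is new, unique, unknown or untested is made for them only; others in the source may bear on it.

Measured in a functional assay on A549 cells (Homo sapiens) for antiproliferative activity, read by MTT assay, with a stated time of 72 h; a lower number here means a stronger inhibitor, a higher number a weaker inhibitor:
- compound 1 `CCCCCCCCCCNC[C@@H]1OC[C@H](N)[C@@H]1O`: 47800 nM
- compound 2 `CCCCCCCCNC[C@@H]1OC[C@H](N)[C@@H]1O`: > 128000 nM
- compound 3 `CCCCCCCCCCCCNC[C@@H]1OC[C@H](N)[C@H]1O`: 41100 nM

Compound 2 reads > 128000 nM, which is a limit of the assay and not a number. In this assay compound 3 gives 41100 nM, within the scatter of compound 1 at 47800 nM.

Compound 4 `CCCCCCCCCNC[C@@H]1OC[C@H](N)[C@H]1O` is the next case, and the change is hydrogen in place of propyl on a saturated chain carbon, nine bonds along the chain from an amine nitrogen. The closest guide is another shortening of the chain, an at least 2.6-fold higher number from compound 1 to compound 2 (0.42 log units; beyond the scatter), which lies beyond the scatter, though its core is not identical to that of compound 3. A similar rise in the number is therefore expected here, not a fall. The expected change is a 2.6-fold higher number from compound 3 to compound 4 (0.41 log units; beyond the scatter). For compound 4 the estimate is 105000 nM, with an expected range of 55000 nM to 220000 nM.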

Compound 4, half-maximal inhibitory concentration: > 128000 nM
Compound 4 was reported as a limit; the forecaster's own chance of this, stated with the estimate: 30%; middle value at least 1.2-fold (0.08 log units) from the limit.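

In this assay, replacing propyl with hydrogen on the chain gives an at least 3.1-fold higher number from compound 3 to compound 4 (0.49 log units; beyond the scatter). Shortening the chain therefore raises the number on the core of compound 3 as well, not only on the core of compound 1. Compound 4 reads > 128000 nM, which is a limit of the assay and not a number, so this step gives only a minimum size: the limit of > 128000 nM in this assay, at which 2 of the 4 values shown sit.

The compounds shown leave open whether a chain longer than that of compound 3 would lower the number further. Going by these compounds, how a chain carrying a carboxylic acid would read also remains open.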